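Removing a Fluorine Next Door to the Acid

The source may hold more compounds than are shown below. What is called first, only, known or untested is meant among the compounds shown, and "the series" means these compounds.

Compound 3 `Cc1c(OCCCCOc2ccc(F)c(C(=O)O)c2)ccc(C(=O)CC2CCCC2)c1C` sits at the bottom of the three results seen so far. In an assay on HEK293 cells for positive allosteric modulation of metabotropic glutamate receptor 2 (Rattus norvegicus), read by thallium flux, with a stated time of 2.5 min (a higher number here means a larger maximal response, a lower number a smaller maximal response), compound 3 gives 14.6%. Compound 1 `Cc1c(OCCCCOc2ccc(C(=O)O)cc2)ccc(C(=O)CC2CCCC2)c1C` gives 16.2%, a result that, as the change a number 1.6 percentage points lower from compound 1 to compound 3 (within the scatter) shows, is not separable from that of compound 3. Compound 2 `Cc1c(OCCCCOc2cccc(C(=O)O)c2)ccc(C(=O)CC2CCCC2)c1O` gives 80.6%, far above compound 3, but compound 2 differs from the others in two places at once, so its number tells only that a large response is possible within this family.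

Compound 4 `Cc1c(OCCCCOc2cccc(C(=O)O)c2)ccc(C(=O)CC2CCCC2)c1C` is compound 3 with one atom taken away: hydrogen in place of fluoro on an aromatic carbon. Among the compounds with values here, the only measured step that touches a fluorine is the one between compound 1 and compound 3, and it was within the scatter. That step also moved the carboxy group, so it speaks to the present change only indirectly. The expectation is therefore a small movement, if any, with a modest upward lean because compound 2, which shares the 3-carboxyphenyl group, gives 80.6%. Compound 4 is estimated at 28% in this assay, within a range of 8% to 65%. The expected step is a number 13.4 percentage points higher from compound 3 to compound 4 (beyond the scatter).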

Compound 4, largest response reached (reported as percent of maximum), in percent of the reference or control that the assay uses: 22.4%
Estimate against measurement, compound 4: 5.6 percentage points above, and the stated range covers the measured number.
By their numbers in this assay, from the lowest: compounds 3, 1 and 4 (each within the scatter of the next); then compound 2.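

Taking away the fluoro group, which stands ortho to a carboxy group, gives a number 7.8 percentage points higher from compound 3 to compound 4 (within the scatter) in this assay, so hydrogen and fluoro cannot be told apart at this position on this evidence. The change of 4-carboxyphenyl to 3-carboxyphenyl, now seen without any fluoro group involved, gives a number 6.2 percentage points higher from compound 1 to compound 4 (within the scatter) in the same test, so the earlier step that combined both changes has now been split into two parts, and each part lies within the scatter. The large difference lies elsewhere, since methyl in place of hydroxy on an aromatic carbon of the shared core gives a number 58.2 percentage points lower from compound 2 to compound 4 (beyond the scatter) and so ties the high response of compound 2 to its hydroxy group rather than to the 3-carboxyphenyl group that compound 2 and compound 4 share.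

Still open, on these data alone, is whether a hydroxy group in that place would lift the response with 4-carboxyphenyl or 3-carboxy-4-fluorophenyl as well, and what an amino or methoxy group there would give. Nothing available gives a measured reason for any of these numbers.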